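Swapping azido for amino: a tolerated-dose question

The source may report more compounds than this note shows. Statements on the series, on what has been measured and on what is new or still open speak of the compounds shown alone.

Measured so far in an ADME assay on Vero 76 cells (Chlorocebus sabaeus) for cytotoxicity, read by microscopy; a higher number here means that more compound is tolerated, a lower number that less compound is tolerated:
Compound 1 `CSc1nc(N[C@@H](C2CC2)C(C)(C)O)c2ccn([C@H]3[C@H](O)[C@H](O)[C@]4(CO)C[C@H]34)c2n1`: > 100000 nM (a limit of the assay)
Compound 2 `O[C@@H]1[C@H](O)[C@@H]2C[C@@H]2[C@H]1n1ccc2c(NC(C3CC3)C3CC3)nc(I)nc21`: 100000 nM
Compound 3 `CC(C)[C@@H](Nc1nc(Cl)nc2c1ncn2[C@H]1[C@H](O)[C@H](O)[C@]2(CN=[N+]=[N-])C[C@H]12)C1CC1`: 32000 nM

Only two of these results are true numbers, since the result for compound 1 is a limit. Of those two, compound 3 has the lower, at 32000 nM, so less of it is tolerated. Its gap to compound 2, at 100000 nM, lies beyond the usual scatter.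

The next compound is compound 4 `CC(C)[C@@H](Nc1nc(Cl)nc2c1ncn2[C@H]1[C@H](O)[C@H](O)[C@]2(CN)C[C@H]12)C1CC1`. It differs from compound 3 in one place: amino in place of azido on a saturated chain carbon bound to a saturated ring carbon, or azidomethyl to aminomethyl (amino in place of azido on a saturated chain carbon bound to a saturated ring carbon).

Going by the values given here, no pair of measured compounds differs in just one place, so this assay offers no direct guide to this change. Compound 3 alone carries azido, while compound 2, without it, stands at 100000 nM. That comparison is weak, as these compounds differ elsewhere too, so only a slight upward shift is expected. The expected step, a 1.6-fold higher number from compound 3 to compound 4 (0.19 log units; within the scatter), would stay within the usual scatter. For compound 4 the estimated value is 50000 nM, with an expected range from 18000 nM to 100000 nM.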

Compound 4, half-maximal cytotoxic concentration: 32000 nM
Compound 4: middle estimate off by 1.6-fold (0.19 log units), on the high side; measured number inside the range.
By their numbers in this assay, from the lowest: compounds 3 and 4 (each within the scatter of the next); then compound 2.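

In this assay, going by these compounds alone, this pair gives the first direct reading of a change in one place: the swap of azido for amino on a saturated chain carbon bound to a saturated ring carbon shows no change at the digits printed from compound 3 to compound 4 (within the scatter) for this pair. Azidomethyl and aminomethyl therefore cannot be told apart by this read-out on this core, although the entering group is smaller and adds a hydrogen-bond donor. Within the data shown here, both compounds give true numbers rather than a limit, so the comparison can be read directly and is not hidden by the top of the assay's range, which only one compound reaches: the limit of > 100000 nM in this assay, at which 1 of the 4 values shown sits.

The compounds shown leave open whether other groups at this place, such as a carboxylic acid, an acetamide or a longer chain carrying an amine, would also stay within the scatter of this pair. They also leave open whether the same swap would read alike with the rest of the molecule altered, since this one pair shows it on a single core with a single set of other groups.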